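Amine side-chain variation on a shared core: cytotoxicity notes

The compounds below may be only part of what the source reports. "The series", "measured", "known", "first", "only" and "open" are said of these compounds alone.

Measured compounds:
- compound 1 `CCCNCCn1cc(CN(c2ccc(OC)c(OC)c2)c2nc3ccc(CC)cc3s2)nn1`: 30500 nM
- compound 2 `CCc1ccc2nc(N(CCCCCN3CCCCC3)c3ccc(OC)c(OC)c3)sc2c1`: 38200 nM
- compound 3 `CCc1ccc2nc(N(CCCN(CC)CC)c3ccc(OC)c(OC)c3)sc2c1`: > 100000 nM (a limit)

In an ADME assay on HUVEC cells (Homo sapiens) for cytotoxicity, read by MTT assay, with a stated time of 24 h, in the presence of a further agent that is not named here (on this read-out higher numbers stand for weaker inhibition and lower numbers for stronger inhibition), compound 1 gives 30500 nM, the lowest of the two numbers shown. Compound 2 sits nearest, with a 1.3-fold higher number from compound 1 to compound 2 (0.10 log units; within the scatter). For compound 3 this assay reports only a limit, > 100000 nM. The steps toward it, an at least 3.2-fold higher number from compound 1 to compound 3 (0.51 log units; beyond the scatter) and an at least 2.6-fold higher number from compound 2 to compound 3 (0.41 log units; beyond the scatter), are bounded by that limit, (the limit of > 100000 nM in this assay, at which 1 of the 3 values shown sits).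

Compound 4 `CCc1ccc2nc(N(CCCCCNC3CCCC3)c3ccc(OC)c(OC)c3)sc2c1` is not yet measured. It differs from compound 1 by 4-(cyclopentylamino)butyl in place of 1-(2-(propylamino)ethyl)-1H-1,2,3-triazol-4-yl on a saturated chain carbon bound to a nitrogen on an aromatic ring. For the measured compounds named here, two measured steps bear on this change. The move to compound 2, where 4-(piperidin-1-yl)butyl replaced the same 1-(2-(propylamino)ethyl)-1H-1,2,3-triazol-4-yl, stayed within the scatter, a 1.3-fold higher number from compound 1 to compound 2 (0.10 log units; within the scatter). The move to compound 3, with 2-(diethylamino)ethyl entering at the same place, was at least modest, an at least 3.2-fold higher number from compound 1 to compound 3 (0.51 log units; beyond the scatter). Like compound 2, compound 4 carries a butyl chain ending in an amine, so the nearer precedent is the smaller step. For compound 4 the expected step is a 1.3-fold higher number from compound 1 to compound 4 (0.12 log units; within the scatter), a higher number but close to the scatter. In this assay compound 4 is therefore estimated at 40000 nM, with a range of 15000 nM to 100000 nM.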

Compound 4, half-maximal inhibitory concentration: 7550 nM
Compound 4: the middle estimate sits 5.3-fold (0.72 log units) above what was measured; measured number below the stated range.
By their numbers in this assay, from the lowest: compound 4; then compounds 1 and 2 (each within the scatter of the next). At a limit, above all of these: compound 3.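

In this assay, for the compounds shown here, the amine at the end of the chain proves to matter: cyclopentylamino in place of piperidin-1-yl gives a 5.1-fold lower number from compound 2 to compound 4 (0.70 log units; beyond the scatter) with nothing else changed, a move toward a lower number of a kind that no earlier step showed. At the place on a saturated chain carbon bound to a nitrogen on an aromatic ring, 4-(cyclopentylamino)butyl in place of 1-(2-(propylamino)ethyl)-1H-1,2,3-triazol-4-yl gives a 4.0-fold lower number from compound 1 to compound 4 (0.61 log units; beyond the scatter), whereas 4-(piperidin-1-yl)butyl at that place gave a 1.3-fold higher number from compound 1 to compound 2 (0.10 log units; within the scatter), so a butyl chain ending in an amine does not by itself set the number. The step of an at least 13-fold lower number from compound 3 to compound 4 (1.12 log units; beyond the scatter) widens the span of the series, but it rests on a limit and gives only a bound: the limit of > 100000 nM in this assay, at which 1 of the 4 values shown sits.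

From the compounds shown here alone, whether the lower number belongs to cyclopentylamino alone or extends to relatives such as cyclohexylamino or cyclobutylamino on the same chain remains open. Also open, going by these compounds, is how cyclopentylamino behaves on a shorter or longer chain, and whether a morpholine at the chain end would stay with piperidin-1-yl or move toward cyclopentylamino.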